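Ortho halogen swap on the phenoxy ring

The source may hold more compounds than are shown below. What is called first, only, known or untested is meant among the compounds shown, and "the series" means these compounds.

Measured so far:
compound 1 `O=C(O)c1cncc(-c2ccc(N3CCC(Oc4ccccc4C(F)(F)F)CC3)nn2)c1` 1300 nM
compound 2 `O=C(O)c1cncc(-c2ccc(N3CCC(Oc4ccccc4Cl)CC3)nn2)c1` 1890 nM

In an assay on cells (Hepatocyte, strain Sprague-Dawley) for inhibition of acyl-CoA desaturase 1 (Rattus norvegicus), read by HPLC (on this read-out lower numbers stand for stronger inhibition and higher numbers for weaker inhibition), compound 2 gives 1890 nM, the highest of the two numbers; its nearest neighbour is compound 1, a step of a 1.5-fold higher number from compound 1 to compound 2 (0.16 log units; within the scatter). Within the data shown here, that one step, chloro in place of trifluoromethyl on an aromatic carbon, is the only measured change and stays within the scatter.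

Compound 3 `O=C(O)c1cncc(-c2ccc(N3CCC(Oc4ccccc4Br)CC3)nn2)c1` is unmeasured. It differs from compound 2 by bromo in place of chloro on an aromatic carbon; the place is an aromatic carbon of a six-membered aromatic ring of carbon only, ortho to a large group. Among the measured compounds shown here, the step from compound 1 to compound 2 bears on it as the sole precedent at this position and was within the scatter, so no step beyond the scatter is expected in this assay in either direction. Compound 3 is therefore estimated at 1700 nM, range 800 nM to 3600 nM, an expected step of a 1.1-fold lower number from compound 2 to compound 3 (0.05 log units; within the scatter).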

Compound 3, half-maximal inhibitory concentration: 1640 nM
The estimate for compound 3 lay 1.0-fold (0.02 log units) above the measured number; the measured number falls inside the stated range.
By their numbers in this assay, from the lowest: compounds 1, 3 and 2 (each within the scatter of the next).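

In this assay, a second swap at this aromatic carbon, ortho to a large group, gives a 1.2-fold lower number from compound 2 to compound 3 (0.06 log units; within the scatter), and the direct comparison with the trifluoromethyl compound gives a 1.3-fold higher number from compound 1 to compound 3 (0.10 log units; within the scatter); both steps lie within the scatter. The position now has three substituents, trifluoromethyl, chloro and bromo, and all three pairs lie within the scatter, so this read-out does not separate these groups at this place. Nothing at hand explains why these three compounds read alike.

Open, going by these compounds, is whether a group of another kind at this carbon, such as an amine, a methoxy or a plain hydrogen, would give a step beyond the scatter. Also open, on these data alone, is whether bromo and chloro still read alike when an amide stands in place of the carboxylic acid on the shared core.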